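This account rests on a few compounds, and the source may have more. Where it says the series, first, only, none or still open, it means among the compounds named here.

Measured so far in a functional assay for agonist activity at Free fatty acid receptor 1 (Homo sapiens), read by FLIPR, in the presence of a further agent that is not named here; on this read-out higher numbers stand for an effect only at larger amounts of compound and lower numbers for an effect already at smaller amounts:

Compound 1 `O=C1NC(=O)C(Cc2ccc(Oc3ccc(C(F)(F)F)cc3Cl)cc2)S1` gives 78 nM.
Compound 2 `O=C1NC(=O)C(Cc2ccc(Oc3cc(C(F)(F)F)ccn3)cc2)S1` gives 237 nM.
Compound 3 `O=C1NC(=O)C(Cc2ccc(Sc3ccccc3)cc2)S1` gives 5060 nM.

Compound 3 stands at the highest of the three numbers in this assay; its nearest neighbour is compound 2, and the gap to it is well beyond the scatter, while the gap to compound 1 is wider still. Compound 4 `O=C1NC(=O)C(Cc2ccc(Oc3ccccc3)cc2)S1` has not been measured. It differs from compound 3 in one place: phenoxy in place of phenylsulfanyl on an aromatic carbon. Among the measured compounds shown here, no measured pair shows exactly this exchange, so the expectation rests on what the three values show. The two compounds built with a phenoxy-type link, compound 1 and compound 2, both sit far lower than compound 3, though each also carries further groups on the outer ring that compound 4 lacks. Compound 4 is therefore expected to sit lower than compound 3, with the step of a 3.4-fold lower number from compound 3 to compound 4 (0.53 log units; beyond the scatter) judged beyond the scatter but well short of the gap to compound 1 or compound 2. The estimate for compound 4 in this assay is 1500 nM, with a range from 400 nM to 6000 nM.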

Compound 4, half-maximal effective concentration: 307 nM
Estimate against measurement, compound 4: 4.9-fold (0.69 log units) above, outside the stated range (below it).
By their numbers in this assay, from the lowest: compound 1; then compounds 2 and 4 (each within the scatter of the next); then compound 3.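

In this assay the exchange of phenylsulfanyl for phenoxy on an aromatic carbon, para to a group of 8 heavy atoms, gives a 16-fold lower number from compound 3 to compound 4 (1.22 log units; beyond the scatter) and counts as a large step. Among the compounds shown here, compounds 1 and 2 also carry a phenoxy-type link, but each has further groups on the outer ring, so they could not separate the link from those groups; this pair can, as the outer ring is bare on both sides and the entering and leaving groups match in heavy-atom count, donors and acceptors, leaving the swap of sulfur for oxygen as the only change. Nothing in the information available explains why this single-atom exchange has so large an effect.

The compounds shown leave open whether the exchange would have the same weight on an outer ring bearing chlorine and trifluoromethyl, as in compound 1, or a ring nitrogen, as in compound 2. They also leave open how a methylene or an amine link would stand at this position compared with the oxygen and sulfur links.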